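Exchanging the naphthalen-1-yl sulfonamide group on a shared core

This account rests on a few compounds, and the source may have more. Where it says the series, first, only, none or still open, it means among the compounds named here.

Of the compounds shown here, three sharing one core have been measured. In a functional assay on MCF7 cells (Homo sapiens) for antiproliferative activity, read by MTT assay, with a stated time of 72 h (a lower number here means a stronger inhibitor, a higher number a weaker inhibitor), compound 1 (`Cc1ccc(N(C)S(=O)(=O)C2CC3OC2C(c2ccc(NC(=O)CCCCCCC(=O)O)cc2)=C3c2ccc(O)cc2)cc1`) gives 23200 nM, compound 2 (`COc1cccc(N(C)S(=O)(=O)C2CC3OC2C(c2ccc(NC(=O)CCCCCCC(=O)O)cc2)=C3c2ccc(O)cc2)c1`) gives 39400 nM and compound 3 (`CN(c1cccc2ccccc12)S(=O)(=O)C1CC2OC1C(c1ccc(NC(=O)CCCCCCC(=O)O)cc1)=C2c1ccc(O)cc1`) gives 14000 nM. Compound 3 shares the low end of these numbers with compound 1, as two steps show: a 1.7-fold lower number from compound 1 to compound 3 (0.22 log units; within the scatter) and a 2.8-fold lower number from compound 2 to compound 3 (0.45 log units; beyond the scatter). The third step, a 1.7-fold higher number from compound 1 to compound 2 (0.23 log units; within the scatter), also stays small.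

Compound 4 (`CCN(c1ccc(OC)cc1)S(=O)(=O)C1CC2OC1C(c1ccc(NC(=O)CCCCCCC(=O)O)cc1)=C2c1ccc(O)cc1`) has not yet been measured. Its difference from compound 3 lies in one place: ethyl(4-methoxyphenyl)amino in place of methyl(naphthalen-1-yl)amino on a sulfonyl sulfur. Among the measured compounds shown here, no measured step covers the ethyl group, so that part of the change remains untested. The closest evidence is compound 2, which also carries a methoxyphenyl group, although at a different position, and its step to the naphthalen-1-yl compound is a 2.8-fold lower number from compound 2 to compound 3 (0.45 log units; beyond the scatter). In this assay, a modest move to a higher number is therefore expected, though it may not exceed the scatter. The expected step is a 1.9-fold higher number from compound 3 to compound 4 (0.29 log units; within the scatter). For compound 4 the estimated value is 27000 nM, with an expected range of 13000 nM to 55000 nM.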

Compound 4, half-maximal inhibitory concentration: 20300 nM
Estimate against measurement, compound 4: 1.3-fold (0.12 log units) above; measured number inside the range.
By their numbers in this assay, from the lowest: compounds 3, 4, 1 and 2 (each within the scatter of the next, the first and the last beyond it).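

In this assay, the exchange on the sulfonyl sulfur removes one six-membered aromatic ring of carbon only, brings in a hydrogen-bond acceptor and replaces methyl with ethyl, yet it gives only a 1.5-fold higher number from compound 3 to compound 4 (0.16 log units; within the scatter). Among the compounds shown here, the two other steps to compound 4 are a 1.9-fold lower number from compound 2 to compound 4 (0.29 log units; within the scatter) and a 1.1-fold lower number from compound 1 to compound 4 (0.06 log units; within the scatter), so compound 4 stands within the scatter of all three earlier compounds, and the only step beyond the scatter at this position remains the one between compound 2 and compound 3. No measurement is at hand that could explain this result.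

Ethyl and the 4-methoxyphenyl group enter together in compound 4, so the compounds shown do not separate what each contributes, and they cannot say whether the position of the methoxy group matters apart from the ethyl group. From the compounds shown here alone, it also remains open whether an amine on the aromatic ring, or a propyl chain on the sulfonamide nitrogen, would give a step beyond the scatter.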